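Phenyl for methyl on a flavone-type core: antiproliferative limits

A few compounds are considered here, and "the series" means these few. Any claim that something is new, unique, unknown or untested is made for them only; others in the source may bear on it.

Of the compounds shown here, three have been tested in a functional assay on MDA-MB-231 cells (Homo sapiens) for antiproliferative activity, read by MTT assay, with a stated time of 48 h; on this read-out higher numbers stand for weaker inhibition and lower numbers for stronger inhibition. Compound 1 `Cc1oc2c3c(ccc2c(=O)c1C)OC[C@H]1[C@@H]3C2=C(CC(C)(C)CC2=O)OC1(C)C` gives only a limit of the assay, > 100000 nM. Compound 2 `Cc1oc2c3c(ccc2c(=O)c1-c1ccccc1)OC[C@H]1[C@@H]3C2=C(CC(C)(C)CC2=O)OC1(C)C` likewise gives only a limit, > 100000 nM. Compound 3 `Cc1nn(-c2ccccc2)c2c1[C@@H]1c3c(ccc4c(=O)c(C)c(C)oc34)OC[C@@H]1C(C)(C)O2` also gives only a limit, > 100000 nM. Compound 2 differs from compound 1 by phenyl in place of methyl on an aromatic carbon, and the step that the two limits leave unreadable from compound 1 to compound 2 cannot be sized because of the limit of > 100000 nM in this assay, at which 3 of the 3 values shown sit.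

Compound 4 `Cc1nn(-c2ccccc2)c2c1[C@@H]1c3c(ccc4c(=O)c(-c5ccccc5)c(C)oc34)OC[C@@H]1C(C)(C)O2` is not yet measured. It differs from compound 3 by phenyl in place of methyl on an aromatic carbon, the same change as that from compound 1 to compound 2, at a place described in the same words. The difference between the core of compound 1 and the core of compound 3 is not broken down here.

Since all three measured values sit at the limit, there is no sign that the phenyl for methyl change brings activity into the measurable range. The step that the limit leaves unreadable from compound 3 to compound 4 is therefore expected to be unreadable in the same way. Compound 4 is estimated at 150000 nM, most likely again reported only as a limit.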

Compound 4, half-maximal inhibitory concentration: > 100000 nM
Compound 4 ended at the assay's limit (the forecaster's own chance of this, stated with the estimate: 85%); the middle value does not contradict the limit.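

No size can be given for the step from compound 3 to compound 4, nor for the one from compound 1 to compound 2, because all four results are limits and not numbers: the limit of > 100000 nM in this assay, at which 4 of the 4 values shown sit.

The compounds shown leave open whether phenyl in place of methyl changes activity at all, and what structure would give a measurable value.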